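A few compounds are considered here, and "the series" means these few. Any claim that something is new, unique, unknown or untested is made for them only; others in the source may bear on it.

Of the compounds shown here, three have been measured in a functional assay on CHO cells for antagonist activity at Glucagon receptor (Homo sapiens), read by cAMP accumulation, with stated times of 30 min and 45 min; a lower number here means a stronger inhibitor, a higher number a weaker inhibitor. Compound 2 `CCCCC[C@H](c1ccc(C(=O)NCc2nn[nH]n2)cc1)N1C(=O)C(c2cc(Cl)cc(Cl)c2)=N[C@]12CC[C@@H](C(C)(C)C)CC2` gives 130 nM, the lowest number of the three. For the measured compounds named here, compound 3 `C[C@H](c1ccc(C(=O)NCCC(=O)O)cc1)N1C(=O)C(c2ccccc2F)=N[C@]12CC[C@@H](C(C)(C)C)CC2` gives 350 nM, and compound 1 `CC(C)[C@H](c1ccc(C(=O)NCc2nn[nH]n2)cc1)N1C(=O)C(c2cc(Cl)cc(Cl)c2)=N[C@]12CC[C@@H](C(C)(C)C)CC2` gives 2200 nM; the only measured step that differs in a single place is a 17-fold lower number from compound 1 to compound 2 (1.23 log units; beyond the scatter). Compound 4 `CC1(CC[C@H](c2ccc(C(=O)NCc3nn[nH]n3)cc2)N2C(=O)C(c3cc(Cl)cc(Cl)c3)=N[C@]23CC[C@@H](C(C)(C)C)CC3)CC1` has not yet been measured in this assay; it differs from compound 2 by 1-methylcyclopropyl in place of propyl on a saturated chain carbon, three bonds along the chain from an amide-type nitrogen in a ring and an aromatic carbon, which, cut one bond further out, reads pentyl to 2-(1-methylcyclopropyl)ethyl. Going by the values given here, only the step from compound 1 to compound 2 bears on this change, and only loosely: it traded isopropyl for pentyl on the saturated chain carbon bound to the amide-type nitrogen in a ring and the aromatic carbon, whereas compound 4 keeps a chain there and closes a three-membered ring at its end. Among the compounds with values here, no measured pair tests such a ring. Compound 4 is therefore expected to sit close to compound 2, with a step of a 1.2-fold higher number from compound 2 to compound 4 (0.06 log units; within the scatter) that is not expected to reach beyond the scatter. The estimate for compound 4 is 150 nM, with a range from 50 nM to 500 nM.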

Compound 4, half-maximal inhibitory concentration: 100 nM
The estimate for compound 4 lay 1.5-fold (0.18 log units) above the measured number; the range from low to high includes it.
By their numbers in this assay, from the lowest: compounds 4 and 2 (each within the scatter of the next); then compound 3; then compound 1.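

In this assay, closing a three-membered ring at the end of the chain leaves the reading within the scatter, with 1-methylcyclopropyl in place of propyl giving a 1.3-fold lower number from compound 2 to compound 4 (0.11 log units; within the scatter), so at this position the unbranched end of the pentyl chain in compound 2 is not needed to hold the activity. Set against isopropyl, the 2-(1-methylcyclopropyl)ethyl group gives a 22-fold lower number from compound 1 to compound 4 (1.34 log units; beyond the scatter), so the large step seen earlier with pentyl is now shared by a second, ring-bearing chain. No supporting data explain why these two chains read alike.

The compounds shown leave open how much larger the end of the chain can become, for instance with cyclohexyl or phenyl there. They also leave open whether a chain carrying an ether oxygen or an amine would be accepted at the same position.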